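The compounds below may be only part of what the source reports. "The series", "measured", "known", "first", "only" and "open" are said of these compounds alone.

Compound 1 `Clc1ccccc1-c1cc(-c2cnn(C3CCNCC3)c2)on1` gives 38% in an assay on a protein complex for positive allosteric modulation of Neuronal acetylcholine receptor; alpha4/beta2 (Homo sapiens); on this read-out lower numbers stand for smaller maximal responses and higher numbers for larger maximal responses.
Compound 2 `Fc1ccc(Cl)c(-c2cc(-c3cnn(C4CCNCC4)c3)on2)c1` gives 29% in this assay.
Compound 3 `Clc1sccc1-c1cc(-c2cnn(C3CCNCC3)c2)on1` gives 42% in this assay.

The three compounds share one core and differ only in the group on one aromatic carbon of that core. Compound 3 has the highest of the three numbers, but a number 4 percentage points higher from compound 1 to compound 3 (within the scatter), so compound 1 and compound 3 cannot be told apart; only a number 13 percentage points higher from compound 2 to compound 3 (beyond the scatter) stands out. Compound 4 `Cc1cc(-c2cnn(C3CCNCC3)c2)on1` carries the change (methyl in place of 2-chlorothiophen-3-yl on an aromatic carbon). For the measured compounds named here, no measured step removes the whole ring group for a methyl: a number 9 percentage points lower from compound 1 to compound 2 (within the scatter) and a number 13 percentage points higher from compound 2 to compound 3 (beyond the scatter) merely vary that ring group. Going by the values given here, with no direct precedent, a step of a number 20 percentage points lower from compound 3 to compound 4 (beyond the scatter) toward a smaller maximal response is expected, with wide uncertainty. Compound 4 is estimated at 22%, between 5% and 45%.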

Compound 4, largest response reached (reported as efficacy), in percent of the reference or control that the assay uses: 19%
Estimate against measurement, compound 4: 3 percentage points above; measured number inside the range.
By their numbers in this assay, from the lowest: compounds 4, 2, 1 and 3 (each within the scatter of the next, the first and the last beyond it).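

Methyl in place of the ring group gives a number 23 percentage points lower from compound 3 to compound 4 (beyond the scatter) and a number 19 percentage points lower from compound 1 to compound 4 (beyond the scatter) in this assay while a measurable response remains. With 2-chloro-5-fluorophenyl as the group that leaves, the same kind of swap gives a number 10 percentage points lower from compound 2 to compound 4 (within the scatter) so the size of the drop depends on which ring group is replaced. Nothing available here accounts for this difference. Still open, as far as these compounds go, is whether a plain phenyl or a small cyclopropyl on this carbon would stay nearer compound 3 or compound 4, and how an amine there would behave.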